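A few compounds are considered here, and "the series" means these few. Any claim that something is new, unique, unknown or untested is made for them only; others in the source may bear on it.

Compound 1 `CC1=CC[C@H]2[C@@H]1CC=C(C)[C@@H](CC[C@H]1[C@]3(C)CC[C@H](O)C(C)(C)O[C@H]3CC[C@@]1(C)O)C2(C)C` has no number to its name, only a limit: in a functional assay on MCF7 cells (Homo sapiens) for antiproliferative activity, read by MTT assay, with a stated time of 72 h (a higher number here means a weaker inhibitor, a lower number a stronger inhibitor), compound 1 gives > 50000 nM. Compound 2 `CC1=CC[C@H]2[C@@H]1CC=C(C)[C@@H](CCC1=C(C)CC[C@@H]3OC(C)(C)[C@@H](O)CC[C@@]13C)C2(C)C` is also reported only as a limit, with compound 2 at > 50000 nM. Compound 3 `CC1=CC[C@H]2[C@H](CC[C@]2(C)O)C(C)(C)[C@@H]1CC[C@H]1[C@]2(C)CC[C@H](OC(=O)CCC(=O)O)C(C)(C)O[C@H]2CC[C@@]1(C)O` is a limit too, with compound 3 at > 50000 nM. The measured set therefore comes down to the limit of > 50000 nM in this assay, at which 3 of the 3 values shown sit. Compound 4 `CC1=CC[C@H]2[C@@H]1CC=C(C)[C@@H](CC[C@H]1[C@]3(C)CC[C@H](OC(=O)c4ccc(Cl)cc4)C(C)(C)O[C@H]3CC[C@@]1(C)O)C2(C)C` carries one change from compound 1, (4-chlorophenyl)carbonyl in place of hydrogen on an oxygen on a saturated carbon. For the measured compounds named here, no measured step exists in this assay, so only a modest move towards stronger inhibition is expected, the estimated at least 2.0-fold lower number from compound 1 to compound 4 (0.30 log units; that floor lies within the scatter). For compound 4 the expected value is 25000 nM, with an estimated range of 8000 nM to 60000 nM.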

Compound 4, half-maximal inhibitory concentration: 22000 nM
Beside the measured number, compound 4's estimate is 1.1-fold (0.06 log units) above it; the measured number falls inside the stated range.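

Putting (4-chlorophenyl)carbonyl in place of hydrogen on this oxygen on a saturated carbon gives, in this assay, an at least 2.2-fold lower number from compound 1 to compound 4 (0.35 log units; beyond the scatter). The hydroxy group of compound 1 is therefore a position where a change to the core of compound 1 can bring a measurable number, and compound 4 is the only compound shown with one: the limit of > 50000 nM in this assay, at which 3 of the 4 values shown sit.

As far as these compounds go, what remains open is whether the chlorine matters, as a plain phenylcarbonyl or a 4-methoxyphenylcarbonyl on the same oxygen would show. From the compounds shown here alone, it is equally open how an ester carrying an amine would read here.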